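Extending an Alkyl Chain: What to Expect for Compound 4

The compounds below may be only part of what the source reports. "The series", "measured", "known", "first", "only" and "open" are said of these compounds alone.

Compound 1 `COc1cc(/C=C/c2ccc(C(C)C)cc2)cc(OC)c1OC` gives 11.1 uM in a functional assay on SK-MEL-5 cells (Homo sapiens) for cytotoxicity; a lower number here means that less compound is needed, a higher number that more compound is needed for the effect.
Compound 3 `CCOc1ccc(/C=C\c2cc(OC)c(OC)c(OC)c2)cc1` gives 2.5 uM in this assay.
For compound 2 `COc1cc(/C=C/c2ccc(C(C)(C)C)cc2)cc(OC)c1OC` the reading is only a limit of the assay, > 25 uM, the ceiling described as the limit of > 25 uM in this assay, at which 1 of the 3 values shown sits.

The difference between the cores of compound 1 and compound 3 is not broken down here. From compound 1 to compound 2 the change is methyl in place of hydrogen on a saturated chain carbon bound to an aromatic carbon and two saturated chain carbons, and it produced an at least 2.2-fold higher number from compound 1 to compound 2 (0.35 log units; beyond the scatter). Compound 4 `CCCOc1ccc(/C=C\c2cc(OC)c(OC)c(OC)c2)cc1` carries the same kind of change relative to compound 3: methyl in place of hydrogen on a saturated chain carbon, two bonds along the chain from an oxygen on an aromatic ring. The surroundings are not the same, though: in compound 2 the added methyl sits on a saturated chain carbon bound to an aromatic carbon and two saturated chain carbons, whereas in compound 4 it sits two bonds along the chain from an oxygen on an aromatic ring. Resting on the measured step of an at least 2.2-fold higher number from compound 1 to compound 2 (0.35 log units; beyond the scatter), a smaller loss is expected for compound 4, estimated as a 2.0-fold higher number from compound 3 to compound 4 (0.30 log units; within the scatter). Compound 4 is therefore estimated at 5 uM, most likely between 1.5 uM and 20 uM.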

Compound 4, concentration for half-maximal effect: 1.4 uM
Compound 4: the middle estimate sits 3.6-fold (0.55 log units) above what was measured; measured number below the stated range.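

In this assay, the methyl that turns ethoxy into propoxy gives a 1.8-fold lower number from compound 3 to compound 4 (0.25 log units; within the scatter), so on this core the change has no effect that can be told apart from scatter. The same change does not carry over with the same result from one core to the other: the same change on two cores in this assay, an at least 2.2-fold higher number (0.35 log units; beyond the scatter) from compound 1 to compound 2 and a 1.8-fold lower number (0.25 log units; within the scatter) from compound 3 to compound 4, at least 4.0-fold (0.60 log units) apart, beyond the scatter of two such steps. On these data alone, compound 2 reads > 25 uM, which is a limit of the assay, so the full size of the earlier step remains unknown, and these data do not show what separates the two cores.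

The compounds shown leave open whether a longer chain, such as butoxy, would keep the reading of compound 4. They also leave open how a chain ending in an amine would behave on this core.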